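Nitro on the phenyl of compound 1

The compounds below may be only part of what the source reports. "The series", "measured", "known", "first", "only" and "open" are said of these compounds alone.

compound 1 `C=C(C)C(=O)c1ccc(OCc2nc(-c3ccccc3)cs2)c(C)c1C` gives 3400 nM
compound 2 `C=C(C)C(=O)c1ccc(OCc2nc(-c3ccccc3)cs2)cc1C` gives 4700 nM
compound 3 `C=C(CC)C(=O)c1ccc(OCc2nc(-c3ccc4ccccc4c3)cs2)c(C)c1C` gives 2000 nM

All three values come from a functional assay on HL-60 cells (Homo sapiens) for inhibition, read by trypan blue exclusion, with a stated time of 72 h (a higher number here means a weaker inhibitor of growth, a lower number a stronger inhibitor of growth), and the number for compound 1 is the middle one of the three, within the scatter of each of the others. Still unmeasured is compound 4 `C=C(C)C(=O)c1ccc(OCc2nc(-c3ccc([N+](=O)[O-])cc3)cs2)c(C)c1C` which differs from compound 1 in one place, phenyl to 4-nitrophenyl. The change is nitro in place of hydrogen on an aromatic carbon, para to a large group nitro in place of hydrogen on an aromatic carbon and nothing else differs.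

Among the compounds with values here, the one measured single-place step is a 1.4-fold higher number from compound 1 to compound 2 (0.14 log units; within the scatter) and it concerns hydrogen in place of methyl elsewhere in the molecule, not on the phenyl. Compound 3 differs from compound 1 in more than one place, so compound 3 at 2000 nM does not isolate any single change. Within the data shown here, no measured compound carries a group on that phenyl, so the data give no direction for this change. A step beyond the scatter in this assay is therefore not expected, though the range must stay wide.

The expected step is a 1.1-fold lower number from compound 1 to compound 4 (0.05 log units; within the scatter) and this is an estimate only. For compound 4 the estimated value is 3000 nM with an expected range from 1200 nM to 8000 nM as its limits.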

Compound 4, concentration for 50% growth inhibition: 5100 nM
Beside the measured number, compound 4's estimate is 1.7-fold (0.23 log units) below it; the measured number falls inside the stated range.
By their numbers in this assay, from the lowest: compounds 3, 1, 2 and 4 (each within the scatter of the next, the first and the last beyond it).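

In this assay, the first group placed on the phenyl, nitro on an aromatic carbon para to a large group, gives a step that stays small (a 1.5-fold higher number from compound 1 to compound 4 (0.18 log units; within the scatter)). Within the data shown here, compounds 1, 2 and 3 carry no group on that phenyl, so they could say nothing about this position, and this single step is the first direct reading of it. It shows that, in this one case, entering three heavy atoms with no net charge at this place does not move the number beyond the usual scatter, although a single substituent cannot define a trend for the position.

As far as these compounds go, whether an amine, a carboxylic acid, a methoxy group or a longer chain at the same place would also stay within the scatter remains open, as does whether nitro would give a similar step on the core of compound 2 or compound 3. The compounds shown also come with no measurement that could account for the size of this step.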